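A few compounds are considered here, and "the series" means these few. Any claim that something is new, unique, unknown or untested is made for them only; others in the source may bear on it.

In a functional assay on BT-549 cells (Homo sapiens) for inhibition, read by sulforhodamine B assay, with a stated time of 48 h, tested at 0.01 uM (a higher number here means a weaker effect of the compound at the concentration tested, a lower number a stronger effect), compound 2 `COc1cc(Cl)cc(-c2nn(-c3cccc(NC(=O)Nc4ccc(Cl)c(Cl)c4)c3)cc2-c2ccncc2)c1` gives 96%, the higher of the two numbers shown, though only within the scatter. Compound 1 `O=C(Nc1cccc(-n2cc(-c3ccncc3)c(-c3cc(O)cc(Cl)c3)n2)c1)Nc1ccc(Cl)c(Cl)c1` gives 94%, and the step of a number 2 percentage points higher from compound 1 to compound 2 (within the scatter) changes little. Compound 3 `COc1cc(Cl)cc(-c2nn(-c3cccc(NC(=O)c4cccc(C(F)(F)F)c4)c3)cc2-c2ccncc2)c1` differs from compound 2 by 3-(trifluoromethyl)phenyl in place of (3,4-dichlorophenyl)amino on a carbonyl carbon. Among the measured compounds shown here, no measured step touches this part of the molecule, and both measured values show only a weak effect at this concentration. The step of a number 1 percentage points lower from compound 2 to compound 3 (within the scatter) is therefore expected to stay within the scatter. For compound 3 the estimated value is 95%, with a range from 84% to 104%.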

Compound 3, a percentage reported as activity, at one concentration (the size of the read-out at that concentration, not a potency): 108%
Beside the measured number, compound 3's estimate is 13 percentage points below it; the measured number lies above the stated range.
By their numbers in this assay, from the lowest: compounds 1 and 2 (each within the scatter of the next); then compound 3.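

In this assay, the step of a number 12 percentage points higher from compound 2 to compound 3 (beyond the scatter) is the first shown here to go beyond the scatter, so the group on the carbonyl carbon can move this read-out. Since a higher number means a weaker effect, 3-(trifluoromethyl)phenyl gives no gain over (3,4-dichlorophenyl)amino at this concentration. Nothing available explains the shift. Open, from the compounds shown here alone, is how a plain phenyl, or a phenyl carrying an amine or a carboxylic acid, would read on this carbonyl carbon. Also open, going by these compounds, is whether the step persists at higher concentrations.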